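Carboxyphenyl shift on the cyclobutane carbon in the bile acid series

The source may report more compounds than this note shows. Statements on the series, on what has been measured and on what is new or still open speak of the compounds shown alone.

Two members of the series have numbers in an assay on HEK293 cells for agonist activity at Bile acid receptor (Homo sapiens); on this read-out higher numbers stand for an effect only at larger amounts of compound and lower numbers for an effect already at smaller amounts. Compound 1 `O=C(O)CNC(=O)c1ccc(C2CC2c2ccc(OCc3c(-c4c(Cl)cccc4Cl)noc3C3CC3)cc2Cl)cc1` carries a glycine amide on its phenyl ring and gives 209 nM in this assay. Compound 2 `O=C(O)c1ccc([C@H]2C[C@](O)(c3ccc(OCc4c(-c5c(Cl)cccc5Cl)noc4C4CC4)cc3Cl)C2)cc1`, with a hydroxy-bearing four-membered ring and a direct carboxylic acid, gives 63 nM in this assay, the lowest of the two numbers, with compound 1 higher by a gap that lies beyond the scatter. For the measured compounds named here, no step between compounds that differ in one place is available, so the two values are read side by side only.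

Compound 3 `O=C(O)c1cccc([C@H]2C[C@](O)(c3ccc(OCc4c(-c5c(Cl)cccc5Cl)noc4C4CC4)cc3Cl)C2)c1` follows from compound 2 by a single rearrangement: 3-carboxyphenyl in place of 4-carboxyphenyl on a saturated ring carbon. Nothing measured in the series shows how moving the acid on that ring acts. The expected step from compound 2 to compound 3 in this assay is a 2.4-fold higher number from compound 2 to compound 3 (0.38 log units; beyond the scatter), a modest rise that may fall within the scatter. The value estimated for compound 3 in this assay is 150 nM, with a range from 40 nM to 600 nM.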

Compound 3, half-maximal effective concentration in the Bile acid receptor assay: 25 nM
Compound 3: the middle estimate sits 6.0-fold (0.78 log units) above what was measured, and the stated range ends above it.
By their numbers in the Bile acid receptor assay, from the lowest: compound 3; then compound 2; then compound 1.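

Working notes: on the saturated ring carbon of the four-membered ring, the placement of the acid on the phenyl ring carries a readable effect in the Bile acid receptor assay, with a 2.5-fold lower number from compound 2 to compound 3 (0.40 log units; beyond the scatter) for 3-carboxyphenyl in place of 4-carboxyphenyl. In a physicochemical assay for solubility (a higher number here means a more soluble compound, a lower number a less soluble compound), compound 2 gives 192000 nM and compound 3 gives 192000 nM, so this rearrangement separates the pair on the receptor read-out only. No measured evidence accounts for the step.

Open, going by these compounds, is whether the 3-carboxyphenyl gain holds when the carboxylic acid gives way to a tetrazole or is carried on a longer chain. Also open, on these data alone, is how the receptor and solubility read-outs respond if a methoxy group replaces the hydroxy group on the four-membered ring.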